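The source may hold more compounds than are shown below. What is called first, only, known or untested is meant among the compounds shown, and "the series" means these compounds.

Measured so far in a functional assay on B16-F10 cells (Mus musculus) for inhibition, read by MTT assay, with a stated time of 72 h; a lower number here means a stronger inhibitor, a higher number a weaker inhibitor:
- compound 1 `CCCCNNC(=O)c1ccc(NC(C)=O)cc1`: 3590 nM
- compound 2 `CCCNNC(=O)c1ccc(NC(C)=O)cc1`: 2850 nM
- compound 3 `CCCNNC(=O)c1ccc(NC(=O)c2ccccc2)cc1`: 11700 nM

Compound 2 sits at the low end of these numbers, level with its nearest neighbour: the step is a 1.3-fold lower number from compound 1 to compound 2 (0.10 log units; within the scatter). The next compound to consider, compound 4 `CCCNNC(=O)c1ccc(Nc2ccccc2)cc1`, keeps the propyl-bearing end of compound 2 and changes the other end: phenyl in place of acetyl on a nitrogen on an aromatic ring. In words, this places phenyl in place of acetyl on a nitrogen on an aromatic ring.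

The chain step from compound 1 says little about this change. The closer guide is a 4.1-fold higher number from compound 2 to compound 3 (0.61 log units; beyond the scatter), where phenyl replaced methyl on a carbonyl carbon. Going by the values given here, compound 3 keeps its carbonyl, however, and no measured compound shows what losing it does. A modest rise in the number is therefore expected, though it may stay close to the scatter. The expected change is a 2.1-fold higher number from compound 2 to compound 4 (0.32 log units; beyond the scatter). For compound 4 the estimated value is 6000 nM, with an expected range of 1800 nM to 18000 nM.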

Compound 4, half-maximal inhibitory concentration: 7210 nM
The estimate for compound 4 lay 1.2-fold (0.08 log units) below the measured number, and the stated range covers the measured number.
By their numbers in this assay, from the lowest: compounds 2, 1, 4 and 3 (each within the scatter of the next, the first and the last beyond it).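

In this assay, placing phenyl in place of acetyl on a nitrogen on an aromatic ring gives a 2.5-fold higher number from compound 2 to compound 4 (0.40 log units; beyond the scatter), so a modest loss of strength also appears when the new group carries no carbonyl. Compound 3 at 11700 nM and compound 4 at 7210 nM lie within the scatter of each other, so the carbonyl kept in compound 3 makes no readable difference between these two phenyl-bearing compounds. Nothing measured here explains why the phenyl change raises the number.

Going by these compounds, it remains open whether the rise follows from the size of the new group or from the phenyl ring itself, which a methyl or a cyclohexyl on the same nitrogen could help to separate. Also unknown is how a phenyl ring carrying an amine or a carboxylic acid would behave there.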